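The compounds below may be only part of what the source reports. "The series", "measured", "known", "first", "only" and "open" are said of these compounds alone.

Measured compounds:
Compound 1 `Cc1cnc(Nc2ccc(C#N)cc2)nc1Nc1c(F)cc(-c2ccco2)cc1F`: 8100 nM
Compound 2 `Cc1cnc(Nc2ccc(C#N)cc2)nc1Nc1c(F)cc(-c2ccoc2)cc1F`: 4200 nM
Compound 3 `Cc1cnc(Nc2ccc(C#N)cc2)nc1Nc1c(F)cc(-c2cncc(C(F)(F)F)c2)cc1F`: 8200 nM

In a toxicity assay on MT4 cells (Homo sapiens) for cytotoxicity, read by MTT assay, with a stated time of 5 days (a lower number here means that less compound is tolerated, a higher number that more compound is tolerated), compound 2 gives the lowest of the three numbers, yet the step of a 1.9-fold lower number from compound 1 to compound 2 (0.29 log units; within the scatter) and the step of a 2.0-fold higher number from compound 2 to compound 3 (0.29 log units; within the scatter) both lie within the scatter, so the three compounds cannot be told apart. Compound 4 `Cc1cnc(Nc2ccc(C#N)cc2)nc1Nc1c(F)cc(-c2ccc(C#N)nc2)cc1F` differs from compound 2 only in the ring attached to the shared core: 6-cyanopyridin-3-yl in place of furan-3-yl on an aromatic carbon. The three measured steps, a 1.9-fold lower number from compound 1 to compound 2 (0.29 log units; within the scatter), a 1.0-fold higher number from compound 1 to compound 3 (0.01 log units; within the scatter) and a 2.0-fold higher number from compound 2 to compound 3 (0.29 log units; within the scatter), each swap this same ring and each stay within the scatter. A step of similar size is therefore expected here, with no clear direction: a 1.4-fold higher number from compound 2 to compound 4 (0.15 log units; within the scatter). Compound 4 is estimated at 6000 nM, within 2500 nM to 15000 nM.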

Compound 4, half-maximal cytotoxic concentration: 62000 nM
Estimate against measurement, compound 4: 10-fold (1.01 log units) below; measured number above the stated range.
By their numbers in this assay, from the lowest: compounds 2, 1 and 3 (each within the scatter of the next); then compound 4.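

In this assay this position is no longer indifferent to the ring placed on it: 6-cyanopyridin-3-yl gives a 15-fold higher number from compound 2 to compound 4 (1.17 log units; beyond the scatter) and a 7.7-fold higher number from compound 1 to compound 4 (0.88 log units; beyond the scatter) and also a 7.6-fold higher number from compound 3 to compound 4 (0.88 log units; beyond the scatter) as steps beyond the scatter, so more compound is tolerated. Compound 3 also carries a pyridin-3-yl ring yet stays within the scatter of both furans, so a pyridine ring alone does not go with the higher number. No measurement here explains the rise. Open, as far as these compounds go, is whether the nitrile accounts for it: a phenyl ring bearing a nitrile, or the same pyridine bearing an amine or a carboxylic acid instead, would separate the two.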